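Chloro-methylphenyl ether in the pyrrolidine acid series

The source may report more compounds than this note shows. Statements on the series, on what has been measured and on what is new or still open speak of the compounds shown alone.

In an assay on HEK293 cells for binding affinity to Free fatty acid receptor 1 (Homo sapiens), read by scintillation counting and radioligand binding, with a stated time of 1 h (on this read-out lower numbers stand for stronger inhibition and higher numbers for weaker inhibition), compound 3 `COc1ccc(Oc2ccc(N3C[C@@H](C(F)(F)F)C[C@H]3CC(=O)O)cc2)c(C)c1` gives 39 nM, the higher of the two numbers obtained; compound 2 `Cc1cc(OCc2ccccc2)ccc1Oc1ccc(N2C[C@@H](C(F)(F)F)C[C@H]2CC(=O)O)cc1` gives 10 nM, and compound 1 `O=C(O)C[C@@H]1C[C@H](C(F)(F)F)CN1c1ccc(Oc2ccccc2C(F)(F)F)cc1` gives "not determined" (no result reported) in this assay. Among the measured compounds shown here, the one measured step, a 3.9-fold higher number from compound 2 to compound 3 (0.59 log units; beyond the scatter), concerns the same ether oxygen but a different group. Compound 4 `Cc1c(Cl)cccc1Oc1ccc(N2C[C@@H](C(F)(F)F)C[C@H]2CC(=O)O)cc1` differs from compound 3 by 3-chloro-2-methylphenyl in place of 4-methoxy-2-methylphenyl on an oxygen on an aromatic ring. For the measured compounds named here, no measured step bears directly on this exchange, so the expectation rests on the shared core and on compound 3 alone, with no clear direction. Compound 4 is therefore estimated to lie close to compound 3, the expected step being a 1.3-fold higher number from compound 3 to compound 4 (0.11 log units; within the scatter), with an estimate of 50 nM in this assay, ranging from 15 nM to 160 nM.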

Compound 4, inhibition constant: 13 nM
The estimate for compound 4 lay 3.8-fold (0.59 log units) above the measured number; measured number below the stated range.
By their numbers in this assay, from the lowest: compounds 2 and 4 (each within the scatter of the next); then compound 3.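

In this assay, placing 3-chloro-2-methylphenyl instead of 4-methoxy-2-methylphenyl on the oxygen gives a 3.0-fold lower number from compound 3 to compound 4 (0.48 log units; beyond the scatter), showing that this aryl group itself can shift the number beyond the scatter. Compound 4 gives 13 nM and compound 2 gives 10 nM, two values within the scatter of each other, so a number at this level does not depend on the phenyl group of compound 2. No measurement shown explains the change. Chlorine entered and methoxy left together, so the contribution of each remains open. As far as these compounds go, how a nitrile or a fluorine in place of the chlorine would read also remains open.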